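The source may report more compounds than this note shows. Statements on the series, on what has been measured and on what is new or still open speak of the compounds shown alone.

The measured compounds in a functional assay on PC-9 cells (Homo sapiens) for inhibition, read by MTT assay, with a stated time of 72 h; a higher number here means a weaker inhibitor, a lower number a stronger inhibitor:
compound 1 `Cc1ccc(CSc2nc3nc(C)cc(Nc4cc(-c5ccccc5)[nH]n4)n3n2)cc1` gives 7310 nM;
compound 2 `Cc1cc(Nc2ccn(Cc3nc(C)c4ccccc4n3)n2)n2nc(SCc3ccc(Br)cc3)nc2n1` gives 5450 nM;
compound 3 `Cc1cc(Nc2cc(-c3ccccc3)[nH]n2)n2nc(SCCc3ccccc3)nc2n1` gives 4930 nM.

Within this small set compound 2 stands second highest of the three numbers. Its nearest neighbour is compound 3 and its furthest is compound 1, and both of those gaps lie within the scatter, so the three compounds cannot be told apart on these data.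

The unmeasured compound 4 `Cc1cc(Nc2ccn(Cc3ccccc3)n2)n2nc(SCc3ccc(Br)cc3)nc2n1` arises from compound 2 by a single change: phenyl in place of 4-methylquinazolin-2-yl on a saturated chain carbon bound to an aromatic nitrogen. Among the compounds with values here, the only measured step, a 1.5-fold lower number from compound 1 to compound 3 (0.17 log units; within the scatter), concerns a different place, a saturated chain carbon bound to a sulfur, and exchanges one aryl group for another there without moving the number beyond the scatter. Within the data shown here, no measured step touches the group on the saturated chain carbon bound to an aromatic nitrogen, so there is no direct precedent for the change from compound 2 to compound 4.

Since the three numbers hold together within the scatter despite varied aryl groups, compound 4 is expected to stay close to compound 2, with a step of a 1.1-fold lower number from compound 2 to compound 4 (0.04 log units; within the scatter) that lies within the scatter. The estimate for compound 4 in this assay is 5000 nM, with a range from 2000 nM to 12000 nM.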

Compound 4, half-maximal inhibitory concentration: > 50000 nM
Compound 4 gave a limit, no number; the forecaster's own chance of this, stated with the estimate: 5%; middle value at least 10-fold (1.00 log units) from the limit.
By their numbers in this assay, from the lowest: compounds 3, 2 and 1 (each within the scatter of the next). At a limit, above all of these: compound 4.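

In this assay, the group on the saturated chain carbon bound to an aromatic nitrogen proves to matter: phenyl in place of 4-methylquinazolin-2-yl gives an at least 9.1-fold higher number from compound 2 to compound 4 (0.96 log units; beyond the scatter). Within the data shown here, the only earlier step, a 1.5-fold lower number from compound 1 to compound 3 (0.17 log units; within the scatter), concerned a different place, a saturated chain carbon bound to a sulfur, and so said nothing about this position. The value of compound 4 is a limit and not a number: the limit of > 50000 nM in this assay, at which 1 of the 4 values shown sits.

The change removes a six-membered aromatic ring with 2 hetero atoms and 2 hydrogen-bond acceptors together, so the compounds shown leave open which part of 4-methylquinazolin-2-yl carries the step; pyridin-2-yl, pyrimidin-2-yl or quinazolin-2-yl without the methyl on the same saturated chain carbon would begin to separate these parts. They also leave open whether a morpholine, an amine or a carboxylic acid in place of phenyl at this position would return a number rather than a limit in this assay.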